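Compound 4 in the thiophene-to-phenyl swap

A few compounds are considered here, and "the series" means these few. Any claim that something is new, unique, unknown or untested is made for them only; others in the source may bear on it.

Measured in a functional assay on RAW264.7 cells (Mus musculus) for cytotoxicity, read by MTT assay, with a stated time of 48 h; on this read-out higher numbers stand for weaker inhibition and lower numbers for stronger inhibition:
compound 1 `CS(=O)(=O)c1ccc(Cc2nnc3n2N=C(c2ccccc2)CS3)cc1` gives 25000 nM
compound 2 `CS(=O)(=O)c1ccc(Cc2nnc3n2N=C(c2cc(Cl)sc2S(N)(=O)=O)CS3)cc1` gives > 100000 nM as a limit
compound 3 `CS(=O)(=O)c1ccc(Cc2nnc3n2N=C(c2cc(Cl)sc2Cl)CS3)cc1` gives > 100000 nM as a limit

Compound 3 stands at > 100000 nM in this assay and this is a limit, not a number. It is one of the two compounds at the limit of > 100000 nM in this assay, at which 2 of the 3 values shown sit, so its true position is not known.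

The next structure is compound 4 `CS(=O)(=O)c1ccc(Cc2nnc3n2N=C(c2ccc(Cl)cc2Cl)CS3)cc1`, reached by 2,4-dichlorophenyl in place of 2,5-dichlorothiophen-3-yl on a carbon with a double bond to nitrogen. The change puts 2,4-dichlorophenyl in place of 2,5-dichlorothiophen-3-yl on a carbon with a double bond to nitrogen. The entering group pairs the phenyl ring of compound 1 with the chloro substituents of compound 3.

For the measured compounds named here, two measured steps bear on this: an at least 4.0-fold higher number from compound 1 to compound 3 (0.60 log units; beyond the scatter) and an at least 4.0-fold higher number from compound 1 to compound 2 (0.60 log units; beyond the scatter). Both leave phenyl and both run towards weaker inhibition. The third, a step that the two limits leave unreadable from compound 2 to compound 3, adds nothing. Going by the values given here, no measured step changes only the ring while keeping the chloro substituents, so the expectation is loose. Compound 4 is expected to fall between compound 1 and the limit, and it may well reach the limit too. The expected step is an at least 1.6-fold lower number from compound 3 to compound 4 (0.22 log units; that floor lies within the scatter), towards stronger inhibition and read against a limit. The estimate for compound 4 is 60000 nM (expected range 20000 nM to 150000 nM).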

Compound 4, half-maximal inhibitory concentration: > 100000 nM
Compound 4 ended at the assay's limit (the forecaster's own chance of this, stated with the estimate: 45%); middle value at least 1.6-fold (0.22 log units) from the limit.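

In this assay, an at least 4.0-fold higher number from compound 1 to compound 4 (0.60 log units; beyond the scatter), so the move away from phenyl towards weaker inhibition no longer depends on a thiophene ring: 2,4-dichlorophenyl shows it too. The value of compound 4 is a limit, so the steps linking compound 2, compound 3 and compound 4 cannot be read, and no order can be given among these three groups on this carbon. Compound 1 is now the only one of the four with a number rather than a limit, and the remaining compounds all sit at the same limit: the limit of > 100000 nM in this assay, at which 3 of the 4 values shown sit.

As far as these compounds go, whether a single chloro on the phenyl ring is already enough for this shift, and which of the two chloro substituents of 2,4-dichlorophenyl counts for more, stays open. In this assay compound 1 gives 25000 nM. Also open, from the compounds shown here alone, is whether an amine or a carboxylic acid on that phenyl ring would keep the read-out close to that of compound 1 or would send it to the limit as well.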